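A few compounds are considered here, and "the series" means these few. Any claim that something is new, unique, unknown or untested is made for them only; others in the source may bear on it.

In a functional assay on DU-145 cells (Homo sapiens) for antiproliferative activity, read by WST assay, with a stated time of 3 days (on this read-out lower numbers stand for stronger inhibition and higher numbers for weaker inhibition), compound 1 (`CCCOc1c(-c2cc(OC)c(OC)c(OC)c2)oc2ccccc2c1=O`) gives 2800 nM. Compound 2 (`CCCCOc1c(-c2cc(OC)c(OC)c(OC)c2)oc2ccccc2c1=O`) gives no number, only a limit of the assay: > 50000 nM. Compound 3 (`CCCCCCCOc1c(-c2cc(OC)c(OC)c(OC)c2)oc2ccccc2c1=O`) likewise gives only a limit: > 50000 nM. Compound 2 therefore stands at the limit of > 50000 nM in this assay, at which 2 of the 3 values shown sit.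

The next structure is compound 4 (`COc1cc(-c2oc3ccccc3c(=O)c2OC(C)C)cc(OC)c1OC`), and the change is isopropyl in place of butyl on an oxygen on an aromatic ring. In words, this is isopropyl in place of butyl on an oxygen on an aromatic ring.

Within the data shown here, two measured steps bear on it, both large and beyond the scatter: an at least 17-fold higher number from compound 1 to compound 2 (1.25 log units; beyond the scatter), and an at least 17-fold higher number from compound 1 to compound 3 (1.25 log units; beyond the scatter). The third, a step that the two limits leave unreadable from compound 2 to compound 3, adds nothing. Going from butyl to isopropyl removes one carbon, which partly reverses the first step, although no isopropyl compound has been measured yet. Compound 4 is therefore expected to land nearer to compound 1 at 2800 nM. Compound 4 could, however, also stay at the limit of the assay. The expected change is an at least 8.3-fold lower number from compound 2 to compound 4 (0.92 log units; beyond the scatter), a large move toward a lower number. For compound 4 the estimated value is 6000 nM, with an expected range of 1500 nM to 30000 nM.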

Compound 4, half-maximal inhibitory concentration: > 50000 nM
Compound 4: no number, only a limit; the forecaster's own chance of this, stated with the estimate: 30%; at least 8.3-fold (0.92 log units) between middle value and limit.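

Until now, only lengthening the chain on this oxygen had been seen to cost activity, and compound 4 shows that a short group is not enough on its own. In this assay, exchanging propyl for isopropyl gives an at least 17-fold higher number from compound 1 to compound 4 (1.25 log units; beyond the scatter), so even this small change at the same oxygen takes the compound out of the measurable range. Of the four groups on this oxygen, only the propyl of compound 1 gives a number, and the other three compounds stop at the same limit: the limit of > 50000 nM in this assay, at which 3 of the 4 values shown sit.

The steps linking compound 4 to compound 2 and to compound 3 join two limits and cannot be read. On these data alone, whether a smaller group on this oxygen, such as methyl or ethyl, or a chain ending in an amine, would give a lower number than compound 1 at 2800 nM stays open.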